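Cytotoxicity of Thymidine Urea Analogues in Human Lung Fibroblasts

The compounds below may be only part of what the source reports. "The series", "measured", "known", "first", "only" and "open" are said of these compounds alone.

Three compounds were tested in an ADME assay on MRC5 cells (Homo sapiens) for cytotoxicity; a higher number here means that more compound is tolerated, a lower number that less compound is tolerated. Compound 1 `Cc1cn([C@@H]2C[C@H](O)[C@@H](CNC(=O)Nc3ccc(Cl)cc3)O2)c(=O)[nH]c1=O` gives > 50000 nM, which is a limit of the assay and not a number. Compound 2 `COc1ccc(NC(=O)NC[C@H]2O[C@H](n3cc(C)c(=O)[nH]c3=O)C[C@@H]2O)cc1` gives > 50000 nM, again a limit. Compound 3 `Cc1cn([C@@H]2C[C@H](O)[C@@H](CNC(=O)Nc3ccc(OCc4ccc(Cl)cc4)cc3)O2)c(=O)[nH]c1=O` gives > 50000 nM, also a limit. The change from compound 1 to compound 2 is methoxy in place of chloro on an aromatic carbon, and it made a step that the two limits leave unreadable from compound 1 to compound 2. The cores of compound 1 and compound 3 differ by (4-chlorobenzyl)oxy in place of chloro on an aromatic carbon. Compound 4 `COc1ccc(COc2ccc(NC(=O)NC[C@H]3O[C@H](n4cc(C)c(=O)[nH]c4=O)C[C@@H]3O)cc2)cc1` has not yet been measured; it differs from compound 3 by methoxy in place of chloro on an aromatic carbon, the same change in the same place as from compound 1 to compound 2. From compound 3 to compound 4 a step that the limit leaves unreadable from compound 3 to compound 4 is expected, an expectation that rests on (the limit of > 50000 nM in this assay, at which 3 of the 3 values shown sit). Compound 4 is therefore estimated at 100000 nM in this assay.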

Compound 4, half-maximal cytotoxic concentration: > 50000 nM
Compound 4: a limit, no number; the forecaster's own chance of this, stated with the estimate: 85%; the middle value lies beyond the limit too.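

Among these compounds, all four results are limits and not numbers, so no step among compound 1, compound 2, compound 3 and compound 4 can be read: the limit of > 50000 nM in this assay, at which 4 of the 4 values shown sit. Still open is the concentration at which any of these compounds would harm the cells in this assay, and so what the swap from chloro to methoxy changes.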